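Series notes: cytotoxicity in the butylsulfanyl step

A few compounds are considered here, and "the series" means these few. Any claim that something is new, unique, unknown or untested is made for them only; others in the source may bear on it.

The series shares the core of compound 1 `CN(C)c1nc(N)nc2c1ncn2/C=C1/CC1(CO)CO` and varies the group on one aromatic carbon of that core. In an ADME assay on MOLT-3 cells (Homo sapiens) for cytotoxicity, with a stated time of 7 days (on this read-out lower numbers stand for higher toxicity in this test and higher numbers for lower toxicity in this test), compound 1 gives "not determined" (no result reported), so no number of its own is available for it. Compound 2 `CCCCCCOc1nc(N)nc2c1ncn2/C=C1/CC1(CO)CO` carries hexyloxy at the varied position. In this assay compound 2 gives > 20000 nM, which is a limit of the assay and not a number. Among the measured compounds shown here, the only evidence on this read-out is therefore (the limit of > 20000 nM in this assay, at which 1 of the 2 values shown sits), and compound 1 stands without a value beside it.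

Compound 3 `CCCCSc1nc(N)nc2c1ncn2/C=C1/CC1(CO)CO` is the next member to be measured in this assay. Its change from compound 1 is butylsulfanyl in place of dimethylamino on an aromatic carbon. For the measured compounds named here, no step between measured compounds is available to size this change, so no direction can be read from the data; the expectation is of a step within the usual scatter, with the assay most likely again reporting only a limit. In this assay compound 3 is expected to give 20000 nM, with a range from 5000 nM to 80000 nM.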

Compound 3, half-maximal cytotoxic concentration: > 20000 nM
Compound 3 was reported as a limit; the forecaster's own chance of this, stated with the estimate: 70%; the middle value sits exactly at the limit.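

In this assay, among the compounds shown here, compound 2 and compound 3 are both reported only as limits, not numbers, and compound 1 has no result, so no step among them can be read. Left open is whether dimethylamino, hexyloxy and butylsulfanyl differ at all on this read-out, as the data stop at one point: the limit of > 20000 nM in this assay, at which 2 of the 3 values shown sit.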